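This account rests on a few compounds, and the source may have more. Where it says the series, first, only, none or still open, it means among the compounds named here.

Compound 2 `Cc1ccc(Nc2nc(SCc3cn(CC(=O)NC(=O)Nc4ccccn4)nn3)nc(-c3ccc(Br)cc3)c2C#N)cc1` stands at the highest number of the three measured in a functional assay on B16-F10 cells (Mus musculus) for inhibition, read by MTT assay, with a stated time of 72 h (on this read-out higher numbers stand for weaker inhibition and lower numbers for stronger inhibition), giving 8160 nM. In this assay compound 1 `COc1cc(-c2nc(SCc3cn(CC(=O)NC(=O)Nc4ccccn4)nn3)nc(Nc3ccc(C)cc3)c2C#N)cc(OC)c1OC` gives 32 nM and compound 3 `CC(C)c1ccc(Nc2nc(SCc3cn(CC(=O)NC(=O)Nc4ccccn4)nn3)nc(-c3ccc(Br)cc3)c2C#N)cc1` gives 42 nM. The step to compound 4 `Cc1ccc(Nc2nc(SCc3cn(CC(=O)NC(=O)Nc4ccccn4)nn3)nc(-c3ccccc3)c2C#N)cc1` is hydrogen in place of bromo on an aromatic carbon. Within the data shown here, no measured step removes a bromo. Among the measured compounds shown here, the one measured step at the same position, a 260-fold higher number from compound 1 to compound 2 (2.41 log units; beyond the scatter), was large, and a 190-fold lower number from compound 2 to compound 3 (2.29 log units; beyond the scatter) was also large but lies elsewhere on the shared core, so neither step sets the direction here. For compound 4 in this assay a moderately lower number is expected, by about a 2.0-fold lower number from compound 2 to compound 4 (0.31 log units; beyond the scatter), with wide uncertainty. The estimate for compound 4 is 4000 nM, with a range from 600 nM to 25000 nM.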

Compound 4, half-maximal inhibitory concentration: 3300 nM
The estimate for compound 4 lay 1.2-fold (0.08 log units) above the measured number; the range from low to high includes it.
By their numbers in this assay, from the lowest: compounds 1 and 3 (each within the scatter of the next); then compound 4; then compound 2.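

In this assay, hydrogen in place of bromo gives a 2.5-fold lower number from compound 2 to compound 4 (0.39 log units; beyond the scatter), a modest step, so the bromo accounts for little of the weak inhibition seen with compound 2. Phenyl in place of 3,4,5-trimethoxyphenyl still gives a 100-fold higher number from compound 1 to compound 4 (2.01 log units; beyond the scatter), so the large gap at this position remains without the bromo and sets both compound 2 and compound 4 far from compound 1. Nothing available here explains either step.

Open, from the compounds shown here alone, is whether a 4-methoxyphenyl or 4-aminophenyl group would close that gap. Also open, going by these compounds, is whether isopropyl in place of methyl would shift the phenyl compound as it shifted the 4-bromophenyl one.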